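Swapping a Methoxy for a Bromo: Cytotoxicity Outlook

A few compounds are considered here, and "the series" means these few. Any claim that something is new, unique, unknown or untested is made for them only; others in the source may bear on it.

Measured so far in an ADME assay on HEL cells (Homo sapiens) for cytotoxicity, with a stated time of 3 days; on this read-out lower numbers stand for higher toxicity in this test and higher numbers for lower toxicity in this test:
- compound 1 `CCC1(Cc2ccccc2)OS(=O)(=O)C=C1OCc1ccc(OC)cc1`: >= 200000 nM, which is a limit of the assay and not a number.
- compound 2 `CC1(Cc2ccccc2)OS(=O)(=O)C=C1OCc1ccccc1`: > 400000 nM, also a limit of the assay.
- compound 3 `CCC1(Cc2ccccc2)OS(=O)(=O)C=C1OCCCCCCc1ccccc1`: >= 20000 nM, again a limit of the assay.

All three measured compounds share a core and differ in the group carried on the ether oxygen. None of them gave a number in this assay: each reading stopped at a limit, as recorded by the limit of > 400000 nM in this assay, at which 1 of the 3 values shown sits, the limit of >= 20000 nM in this assay, at which 1 of the 3 values shown sits, and (the limit of >= 200000 nM in this assay, at which 1 of the 3 values shown sits). For the measured compounds named here, compound 1 therefore stands at a limit, and the two companions also sit at limits, so no ordering among them can be drawn and no step between measured compounds is known.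

The unmeasured compound 4 `CCC1(Cc2ccccc2)OS(=O)(=O)C=C1OCc1ccc(Br)cc1` arises from compound 1 through a single change: bromo in place of methoxy on an aromatic carbon. Going by the values given here, with no measured step to lean on, and every reading so far at a limit, the expectation rests only on the shared core and the small size of the change.

Compound 4 is expected to reach about 200000 nM in this assay, most likely again reported as a limit, within a range from 50000 nM to 500000 nM. The expected step of a number no higher from compound 1 to compound 4 (the limit leaves the size open) is therefore none beyond the scatter.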

Compound 4, minimum cytotoxic concentration: 80000 nM
The estimate for compound 4 lay 2.5-fold (0.40 log units) above the measured number; low and high end bracket the measured number.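

In this assay compound 4 gives 80000 nM as a plain number, and it is the only compound shown whose reading is not a limit of the assay. Replacing the 4-methoxyphenyl group with a 4-bromophenyl group gives an at least 2.5-fold lower number from compound 1 to compound 4 (0.39 log units; beyond the scatter) and so moves the reading towards higher toxicity in this test, which the earlier readings, all limits, could not show. This place on the aromatic ring, para to a large group, therefore matters for the read-out, although nothing shown here explains why the number changes.

The true size of the step stays unknown, since the reading for compound 1 is only a limit of the assay, and the compounds shown leave open whether this lower number belongs to bromo in particular. A chloro group, a nitrile or an amine at the same place could show whether other replacements for methoxy also lower the number, or whether the reading stays at a limit as it does for compound 1.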